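The source may hold more compounds than are shown below. What is called first, only, known or untested is meant among the compounds shown, and "the series" means these compounds.

Of the compounds shown here, three have been read so far in a physicochemical assay for solubility (on this read-out higher numbers stand for higher solubility and lower numbers for lower solubility), and none of them gives an exact number. Compound 1 (`CCNC(=O)c1cc(C(=O)NC)c(=O)n(Cc2ccccc2)c1`) gives >= 144 ug/mL, which is a limit. Compound 2 (`CNC(=O)c1cc(C(=O)NC2CCC2)cn(Cc2ccccn2)c1=O`), which carries pyridin-2-yl on the saturated chain carbon, gives >= 103 ug/mL, also a limit. Compound 3 (`CNC(=O)c1cc(C(=O)NC2CCC2)cn(Cc2cccc(NC)c2)c1=O`) gives >= 155 ug/mL, and this too is a limit, so it has no exact standing in this assay.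

Compound 4 (`CNC(=O)c1cc(C(=O)NC2CCC2)cn(Cc2cccnc2)c1=O`) has not yet been measured. It has pyridin-3-yl in place of 3-(methylamino)phenyl on a saturated chain carbon bound to an aromatic nitrogen.

Within the data shown here, only one measured step changes the group at this place, and it is a step that the two limits leave unreadable from compound 2 to compound 3. That step offers no size or direction to carry over, so no change beyond the scatter is expected. The estimated step is a step that the limit leaves unreadable from compound 3 to compound 4. For compound 4, the estimate is 160 ug/mL, with an expected range from 90 ug/mL to 320 ug/mL.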

Compound 4, solubility: >= 99 ug/mL
Compound 4 ended at the assay's limit; the forecaster's own chance of this, stated with the estimate: 75%; the middle value lies beyond the limit too.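

In this assay compound 4 gives >= 99 ug/mL, which is a limit and not a number. Compound 2 and compound 3 also stand only as limits, and their steps to compound 4 cannot be read. The compounds shown leave open the exact solubility of each, and whether exchanging these groups changes it at all.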